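The source may hold more compounds than are shown below. What is called first, only, known or untested is meant among the compounds shown, and "the series" means these compounds.

Compound 1 `CN1CCN(CCNCc2cn(-c3ccc(F)cc3F)nc2-c2ccccc2)CC1` — in an ADME assay on Huh-7 cells (Homo sapiens) for cytotoxicity (on this read-out higher numbers stand for lower toxicity in this test and lower numbers for higher toxicity in this test), compound 1 gives > 20000 nM, a limit of the assay and not a number.
Compound 2 `Cc1ccccc1-c1nn(-c2ccc(F)cc2F)cc1CNCCN1CCN(C)CC1` — in this assay compound 2 gives > 20000 nM, again a limit and not a number.
Compound 3 `CN1CCN(CCNCc2cn(-c3ccc(F)cc3F)nc2-c2cccc(Cl)c2)CC1` — in this assay compound 3 gives 15000 nM.

Compound 3 is thus the only one of the three with an actual number; the other two sit at the limit of > 20000 nM in this assay, at which 2 of the 3 values shown sit. Among the measured compounds shown here, the steps that lead to it are an at least 1.3-fold lower number from compound 1 to compound 3 (0.12 log units; that floor lies within the scatter) and an at least 1.3-fold lower number from compound 2 to compound 3 (0.12 log units; that floor lies within the scatter), each with a floor that lies within the scatter, so they say only that the number for compound 3 lies somewhat under a limit. The step that the two limits leave unreadable from compound 1 to compound 2 cannot be read.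

Compound 4 `CN1CCN(CCNCc2cn(-c3ccc(F)cc3F)nc2-c2cccc(N(C)C)c2)CC1` differs from compound 3 by dimethylamino in place of chloro on an aromatic carbon. For the measured compounds named here, the nearest precedent is the exchange on the same ring seen in an at least 1.3-fold lower number from compound 2 to compound 3 (0.12 log units; that floor lies within the scatter), which gave a step whose floor lies within the scatter. Going by the values given here, nothing among the measured steps points to a move beyond the scatter, so the step is expected to be a 1.1-fold higher number from compound 3 to compound 4 (0.05 log units; within the scatter). Compound 4 is therefore expected to give 17000 nM, with a range from 8000 nM to 40000 nM, and a real chance that this assay again returns only a limit.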

Compound 4, half-maximal cytotoxic concentration: > 20000 nM
Compound 4: only a limit was reported; the forecaster's own chance of this, stated with the estimate: 45%; at least 1.1-fold (0.07 log units) between middle value and limit.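

In this assay, dimethylamino in place of chloro on this aromatic carbon, meta to a large group, gives an at least 1.3-fold higher number from compound 3 to compound 4 (0.12 log units; that floor lies within the scatter). Among the compounds shown here, this is the first change at this place that starts from the one compound with a number, and it shows that a substituent here need not give a number at all, since compound 4 returns only a limit, though the floor of the step does not separate that limit from the number for compound 3. Compound 3 therefore stands alone among the compounds shown, with the other three all reported at the same limit: the limit of > 20000 nM in this assay, at which 3 of the 4 values shown sit.

The steps to compound 4 from compound 1 and from compound 2 cannot be read, as both ends of each are limits. On these data alone, how far the values of compound 1, compound 2 and compound 4 lie past that limit stays open, as does whether another group at this place, such as a carboxylic acid, a primary amine or a methoxy group, would give a number clearly apart from that of compound 3.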